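The source may hold more compounds than are shown below. What is called first, only, known or untested is meant among the compounds shown, and "the series" means these compounds.

Measured in an ADME assay on microsomes from liver (Homo sapiens) for metabolic stability, read by LC-MS, using NADPH, with a stated time of 45 min; a lower number here means that the compound disappears faster, a higher number that the compound lasts longer:
- Compound 1 `COc1cnc(O[C@@H]2C[C@H]3C(=O)N[C@]4(C(=O)NS(=O)(=O)C5CC5)C[C@H]4/C=C\CCCC[C@@H](C)[C@H](NC(=O)OC(C)(C)C(F)(F)F)C(=O)N3C2)c2ccccc12`: 0.31 h
- Compound 2 `COc1cnc(O[C@@H]2C[C@H]3C(=O)N[C@]4(C(=O)NS(=O)(=O)C5CC5)C[C@H]4/C=C\CC[C@@H](C)C[C@@H](C)[C@H](NC(=O)OC(C)(C)C(F)(F)F)C(=O)N3C2)c2ccccc12`: 0.198 h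

Compound 2, at 0.198 h, stands within the scatter of compound 1, at 0.31 h. Going by the values given here, the one measured step, a 1.6-fold lower number from compound 1 to compound 2 (0.19 log units; within the scatter), is methyl in place of hydrogen on a saturated ring carbon.

Compound 3 `C[C@@H]1CC/C=C\[C@@H]2C[C@@]2(C(=O)NS(=O)(=O)C2CC2)NC(=O)[C@@H]2C[C@@H](Oc3nccc4ccc(F)cc34)CN2C(=O)[C@@H](NC(=O)OC(C)(C)C(F)(F)F)[C@H](C)C1` differs from compound 2 elsewhere: 7-fluoroisoquinolin-1-yl in place of 4-methoxyisoquinolin-1-yl on an oxygen on a saturated carbon. In words, 7-fluoroisoquinolin-1-yl stands in place of 4-methoxyisoquinolin-1-yl on an oxygen on a saturated carbon. Among the compounds with values here, no measured pair carries this exchange, so the measured step bears on it only weakly and gives it no size. The expectation therefore starts from compound 2 at 0.198 h, and no change beyond the scatter is foreseen, though the uncertainty is wide. The expected move is a 1.3-fold higher number from compound 2 to compound 3 (0.10 log units; within the scatter). For compound 3 the estimated half-life in this assay is 0.25 h, with an expected range of 0.1 h to 0.6 h.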

Compound 3, half-life: 0.167 h
Compound 3: the middle estimate sits 1.5-fold (0.18 log units) above what was measured; the range from low to high includes it.
By their numbers in this assay, from the lowest: compounds 3, 2 and 1 (each within the scatter of the next).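

At this place, on an oxygen on a saturated carbon, the group can differ without a change beyond the scatter: in this assay, 7-fluoroisoquinolin-1-yl in place of 4-methoxyisoquinolin-1-yl gives a small step (a 1.2-fold lower number from compound 2 to compound 3 (0.07 log units; within the scatter)). Going by these compounds alone, the earlier compounds differed only on a saturated ring carbon, so this is the first reading at this place, and it shows that the half-life of compound 3 stays within the scatter of compound 2 without the methoxy group. Nothing measured here offers a reason for this outcome.

The two compounds do not separate the loss of the methoxy group from the gain of the fluorine. On these data alone, it also remains open whether an amine or a carboxylic acid on the isoquinoline would move the half-life beyond the scatter.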